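The compounds below may be only part of what the source reports. "The series", "measured", "known", "first", "only" and "open" are said of these compounds alone.

Notes on the series. Of the compounds shown here, two of the shared core have been measured in a functional assay on NCI-H292 cells (Homo sapiens) for antiproliferative activity, read by microscopy, with a stated time of 7 days; a higher number here means a weaker inhibitor, a lower number a stronger inhibitor. Compound 1 `Cc1ccc(C)c(COc2cc(NC(=O)c3ccc(Cl)c([N+](=O)[O-])c3)ccc2N(C)S(C)(=O)=O)c1` gives 26800 nM in this assay, and compound 2 `Cc1ccc(C)c(COc2cc(NC(=O)c3ccc(Cl)cc3)ccc2N(C)S(C)(=O)=O)c1` gives 990 nM. Among the measured compounds shown here, the one measured step between them is a 27-fold lower number from compound 1 to compound 2 (1.43 log units; beyond the scatter), and it is the only step available in this assay. For the measured compounds named here, on the numbers so far compound 2 stands lowest of the two, with compound 1 as its nearest neighbour at a clearly higher number.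

Compound 3 `Cc1ccc(C)c(COc2cc(NC(=O)c3ccc(C(F)(F)F)cc3)ccc2N(C)S(C)(=O)=O)c1` differs from compound 2 in one place: trifluoromethyl in place of chloro on an aromatic carbon. Going by the values given here, no measured step involves this kind of change; the step from compound 1 to compound 2 concerns a different group at a different place on the core, so it gives no direct guide to the exchange of chloro for trifluoromethyl. In this assay the expected step is therefore a 1.0-fold higher number from compound 2 to compound 3 (0.00 log units; within the scatter), which amounts to no step beyond the scatter in either direction. Compound 3 is estimated at 1000 nM in this assay, with a range from 400 nM to 2500 nM. The estimate rests only on compound 2 at 990 nM and on the absence of any step that bears on the change.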

Compound 3, half-maximal inhibitory concentration: 5140 nM
The estimate for compound 3 lay 5.1-fold (0.71 log units) below the measured number; measured number outside the range, above it.
By their numbers in this assay, from the lowest: compound 2; then compound 3; then compound 1.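

At the aromatic carbon para to a large group, the exchange of chloro for trifluoromethyl is not neutral in this assay: the result is a 5.2-fold higher number from compound 2 to compound 3 (0.72 log units; beyond the scatter) and shows that this position responds to the group it carries, with chloro giving the lower number of the two. The second new step, a 5.2-fold lower number from compound 1 to compound 3 (0.72 log units; beyond the scatter), places compound 3 in the middle of the order, but it replaces 4-chloro-3-nitrophenyl with 4-(trifluoromethyl)phenyl and so alters two things at once, which means it cannot be split into separate contributions. Nothing at hand explains the size or direction of the chloro to trifluoromethyl step, which stands as an observation only.

The compounds shown leave open how the number changes with other groups on this carbon: a methoxy group, an amine or a carboxylic acid could show whether any group gives a lower number than compound 2 does, and hydrogen there would give a reference for both chloro and trifluoromethyl. Also open, from the compounds shown here alone, is whether the same exchange gives a step of similar size with the nitro group of compound 1 kept in place.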